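The source may hold more compounds than are shown below. What is called first, only, known or untested is meant among the compounds shown, and "the series" means these compounds.

Compounds measured so far:
compound 1, `Nc1sc2cnccc2c1C(=O)c1ccccc1`, 0% 
compound 2, `Cc1ccc(C(=O)c2c(N)sc3cnccc23)cc1`, 0% 

In an assay on CHO cells for displacement of a labelled ligand from adenosine receptor A3 (Homo sapiens), tested at 10 uM (a lower number here means less inhibition, a higher number more inhibition at the concentration tested (going by the name of the read-out)), compound 1 gives 0%, and compound 2 gives 0%. Within the data shown here, compound 1 is level with compound 2 at the digits reported; the one step measured, methyl in place of hydrogen on an aromatic carbon, gave no change at the digits printed from compound 1 to compound 2 (within the scatter).

The unmeasured compound 3, `Nc1sc2cnccc2c1C(=O)c1cccs1`, differs from compound 1 as follows: thiophen-2-yl in place of phenyl on a carbonyl carbon. Among the measured compounds shown here, no measured step changes the group on the carbonyl carbon, so the only guidance is the single measured step, which stayed within the scatter, and the fact that both measured compounds sit at the bottom of the scale. Compound 3 is therefore expected to show no change at the digits printed from compound 1 to compound 3 (within the scatter), that is, no step beyond the scatter. The estimate for compound 3 in this assay is 0%, within a range from -8% to 12%.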

Compound 3, a percentage reported as inhibition, at one concentration (the size of the read-out at that concentration, not a potency): 0%
Beside the measured number, compound 3's estimate shows no gap at the digits printed; the measured number falls inside the stated range.
By their numbers in this assay, from the lowest: compounds 1, 2 and 3 (each within the scatter of the next).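

In this assay, thiophen-2-yl in place of phenyl on a carbonyl carbon gave no change at the digits printed from compound 1 to compound 3 (within the scatter). Among these compounds, this is the first measured change of the group on the carbonyl carbon: replacing the six-membered carbon ring with a five-membered ring holding one sulfur atom did not lift compound 3 from 0%, the same printed value as compound 1 at 0%. As both compounds sit at zero, this step cannot show whether the two groups would differ in a compound with measurable inhibition, and nothing available explains the result.

As far as these compounds go, whether a non-aromatic group on the carbonyl carbon, such as an amine, a carboxylic acid or a longer alkyl chain, would give any inhibition at all remains open. The compounds shown also leave open whether any change to the shared core would do so.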